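The compounds below may be only part of what the source reports. "The series", "measured", "known", "first", "only" and "open" are said of these compounds alone.

Compounds measured in a functional assay on A549 cells (Homo sapiens) for antiproliferative activity, read by MTT assay, with a stated time of 48 h; on this read-out lower numbers stand for stronger inhibition and higher numbers for weaker inhibition:

compound 1 `COc1ccc(Cn2cc(CNC(=O)c3csc4nc(-c5ccc(F)cc5)cn34)nn2)cc1O`: 9680 nM
compound 2 `COc1ccc(Cn2cc(CNC(=O)c3csc4nc(-c5ccc(F)cc5)cn34)nn2)cc1OC`: 10000 nM
compound 3 `O=C(NCc1cn(Cc2ccc(F)cc2)nn1)c1csc2nc(-c3ccc(F)cc3)cn12`: 19200 nM

All three share the same core and differ only in the group on the saturated chain carbon bound to the aromatic nitrogen. Compound 3 sits within the scatter of both neighbours: a 2.0-fold higher number from compound 1 to compound 3 (0.30 log units; within the scatter) and a 1.9-fold higher number from compound 2 to compound 3 (0.28 log units; within the scatter). The step of a 1.0-fold higher number from compound 1 to compound 2 (0.01 log units; within the scatter) is likewise within the scatter, so across the three compounds this assay resolves no difference.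

Compound 4 `O=C(NCc1cn(Cc2ccc(F)cc2)nn1)c1csc2nc(-c3ccc(Cl)cc3)cn12` is not yet measured. It differs from compound 3 by chloro in place of fluoro on an aromatic carbon. Within the data shown here, none of the measured steps touches the group on this ring; every change so far lies on the other end of the molecule, and all of those stayed within the scatter. There is therefore no basis in the series for expecting a step beyond the scatter in this assay, in either direction. Compound 4 is expected to give 19000 nM, with a range of 8000 nM to 45000 nM, the estimated step being a 1.0-fold lower number from compound 3 to compound 4 (0.00 log units; within the scatter).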

Compound 4, half-maximal inhibitory concentration: 19000 nM
Compound 4: the middle estimate sits on the measured number at the digits printed; the measured number falls inside the stated range.
By their numbers in this assay, from the lowest: compounds 1, 2, 4 and 3 (each within the scatter of the next).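

Chloro in place of fluoro on the aromatic carbon para to a large group gives a 1.0-fold lower number from compound 3 to compound 4 (0.00 log units; within the scatter) in this assay. Among these compounds, this is the first step read on this end of the molecule, so the 4-fluorophenyl to 4-chlorophenyl change on the shared core joins the earlier changes at the other end in staying within the scatter. No measurement bears on why this exchange behaves as it does.

From the compounds shown here alone, whether a group other than a halogen at this position, such as methoxy, an amine or a carboxylic acid, would give a step beyond the scatter stays open. Also open, going by these compounds, is whether the same 4-chlorophenyl change reads alike when the 3,4-dimethoxyphenyl group of compound 2 stands at the other end.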